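The source may hold more compounds than are shown below. What is called first, only, known or untested is meant among the compounds shown, and "the series" means these compounds.

In a functional assay on HeLa cells (Homo sapiens) for inhibition, with a stated time of 72 h (a higher number here means a weaker inhibitor, a lower number a stronger inhibitor), compound 3 `NC1CCC(Nc2nc(NCc3ccc(-c4ccsc4)nc3)c3ncn(C4CCCC4)c3n2)CC1` gives 75 nM, the lowest number of the three measured, against compound 2 `NC1CCC(Nc2nc(NCc3ccc(-c4ccccc4)cc3)c3ncn(C4CCCC4)c3n2)CC1` at 240 nM and compound 1 `NC1CCC(Nc2nc(NCc3ccc(Br)cc3)c3ncn(C4CCCC4)c3n2)CC1` at 1510 nM. Compound 4 `Nc1ccccc1CNc1nc(NC2CCC(N)CC2)nc2c1ncn2C1CCCC1` carries 2-aminophenyl in place of 6-(thiophen-3-yl)pyridin-3-yl on a saturated chain carbon bound to a nitrogen on an aromatic ring. Going by the values given here, the steps that bear on this are a 6.3-fold lower number from compound 1 to compound 2 (0.80 log units; beyond the scatter), a 3.2-fold lower number from compound 2 to compound 3 (0.51 log units; beyond the scatter) and a 20-fold lower number from compound 1 to compound 3 (1.30 log units; beyond the scatter), all towards a lower number. Among the compounds with values here, no measured compound carries 2-aminophenyl, so the expectation leans on compound 1 at 1510 nM. A large step to a higher number in this assay is expected, estimated as a 27-fold higher number from compound 3 to compound 4 (1.43 log units; beyond the scatter). Compound 4 is estimated at 2000 nM, with an expected range of 500 nM to 8000 nM.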

Compound 4, half-maximal inhibitory concentration: 1030 nM
Compound 4: middle estimate off by 1.9-fold (0.29 log units), on the high side; measured number inside the range.
By their numbers in this assay, from the lowest: compound 3; then compound 2; then compounds 4 and 1 (each within the scatter of the next).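

With 2-aminophenyl on the saturated chain carbon, the series shows a 14-fold higher number from compound 3 to compound 4 (1.14 log units; beyond the scatter) and a 4.3-fold higher number from compound 2 to compound 4 (0.63 log units; beyond the scatter) in place of the 6-(thiophen-3-yl)pyridin-3-yl and 4-phenylphenyl groups. Against 4-bromophenyl, the change gives a 1.5-fold lower number from compound 1 to compound 4 (0.17 log units; within the scatter) and does not separate the two single-ring groups, so among these four compounds only the groups with a second aromatic ring give the lower numbers. No measurement here accounts for these steps. Open, on these data alone, is whether a second aromatic ring added to 2-aminophenyl would restore the lower numbers. Also open, as far as these compounds go, is how a single phenyl ring bearing a carboxylic acid or a longer chain in place of the amine would compare with compound 4.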